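Swapping an aryl amide for propanoyl in pyrazoline cytotoxins

The source may hold more compounds than are shown below. What is called first, only, known or untested is meant among the compounds shown, and "the series" means these compounds.

The measured compounds and their values:
Compound 1 `CCC(=O)N1N=C(C)CC1c1cc(Br)ccc1O`: 50300 nM
Compound 2 `CC1=NN(C(=O)c2ccc(C)cc2)C(c2cc(Br)ccc2O)C1`: 21000 nM
Compound 3 `Cc1ccc(C(=O)N2N=C(c3cc4ccccc4oc3=O)CC2c2ccccc2)cc1`: 31300 nM

All three were tested in a functional assay on MGC-803 cells (Homo sapiens) for cytotoxicity, read by MTT assay, with a stated time of 48 h; a lower number here means a stronger inhibitor, a higher number a weaker inhibitor. In this assay compound 2 gives 21000 nM, and compound 1 gives 50300 nM. The change between them is ethyl in place of 4-methylphenyl on a carbonyl carbon, and it produced a 2.4-fold higher number from compound 2 to compound 1 (0.38 log units; beyond the scatter). Compound 3 carries a different core, and in this assay compound 3 gives 31300 nM; its value lies within the scatter of both compound 2 and compound 1, so no order among them can be stated. The difference between the cores of compound 3 and compound 2 is not broken down here.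

Compound 4 `CCC(=O)N1N=C(c2cc3ccccc3oc2=O)CC1c1ccccc1` has not yet been measured. It differs from compound 3 by ethyl in place of 4-methylphenyl on a carbonyl carbon, and since the place lines match word for word, this is the same change as that from compound 2 to compound 1. On that single precedent, one expects a 2.2-fold higher number from compound 3 to compound 4 (0.35 log units; beyond the scatter), a step of about the same size as the earlier one. Compound 4 is therefore estimated at 70000 nM, with a range from 30000 nM to 170000 nM, resting on one paired observation only.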

Compound 4, half-maximal inhibitory concentration: 5300 nM
For compound 4 the middle estimate is 13-fold (1.12 log units) above the measured one; measured number outside the range, below it.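

In this assay, putting ethyl in place of 4-methylphenyl on the carbonyl carbon gives a 5.9-fold lower number from compound 3 to compound 4 (0.77 log units; beyond the scatter), so on this core the smaller group goes with the stronger inhibition. The same change did not carry over between the two cores, since it moved the number in opposite directions on them: the same change on two cores in this assay, a 2.4-fold higher number (0.38 log units; beyond the scatter) from compound 2 to compound 1 and a 5.9-fold lower number (0.77 log units; beyond the scatter) from compound 3 to compound 4, 14-fold (1.15 log units) apart, beyond the scatter of two such steps

Among these compounds, this shows that, in this series, the result of the swap on one core is no guide to its direction on the other, but with only two pairs it does not show which structural difference between the cores sets the outcome, or what a third core would do.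

The compounds shown leave open how the result on the core of compound 4 depends on the group at the carbonyl carbon, for instance with a methyl, a longer chain such as butyl, or an unsubstituted phenyl there. They also leave open whether a group carrying an amine or a carboxylic acid at that place would follow the ethyl or the 4-methylphenyl result on either core.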